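The source may hold more compounds than are shown below. What is called first, only, known or untested is meant among the compounds shown, and "the series" means these compounds.

Compound 1, with the structure `CCOC(=O)/C=C/c1ccncc1-c1ccc2[nH]ccc2c1`, was tested in a functional assay on MDA-MB-231 cells (Homo sapiens) for inhibition, read by sulforhodamine B assay, with a stated time of 72 h; a lower number here means a stronger inhibitor of growth, a higher number a weaker inhibitor of growth. In this assay compound 1 gives > 10000 nM, which is a limit of the assay rather than a measured number. Compound 2, with the structure `O=C(O)/C=C/c1ccncc1-c1ccc2cc[nH]c2c1`, gives in this assay > 10000 nM, again a limit. Compound 3, with the structure `NC(=O)/C=C/c1ccncc1-c1ccc2ccccc2c1`, gives in this assay > 10000 nM, also a limit. So compound 1 stands at the limit of > 10000 nM in this assay, at which 3 of the 3 values shown sit, and no number separates it from the other two compounds.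

Compound 4, with the structure `CCOC(=O)/C=C/c1ccncc1-c1ccc2c(ccn2C)c1`, differs from compound 1 in one place: methyl in place of hydrogen on an aromatic nitrogen. Among the compounds with values here, no step between two measured compounds is available to set the expected size of this change, and all three measured values sit at the same limit. The step from compound 1 to compound 4 in this assay is therefore expected to be none beyond the usual scatter: the estimate for compound 4 is 15000 nM, with a range from 5000 nM to 50000 nM. The expected step is a step that the limit leaves unreadable from compound 1 to compound 4, meaning no change worth noting.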

Compound 4, concentration for 50% growth inhibition: 10200 nM
Compound 4: middle estimate off by 1.5-fold (0.17 log units), on the high side; the range from low to high includes it.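

No step can be read from compound 1 to compound 4, because compound 1 carries a limit of the assay and not a number: the limit of > 10000 nM in this assay, at which 3 of the 4 values shown sit. The compounds shown leave open whether methyl in place of hydrogen on an aromatic nitrogen changes growth inhibition in this assay at all.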